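The compounds below may be only part of what the source reports. "The series", "measured", "known", "first", "only" and "open" are said of these compounds alone.

Three compounds built on a shared core have numbers in a functional assay on SW-620 cells (Homo sapiens) for cytotoxicity, read by MTT assay, with stated times of 4 h and 72 h, tested at 2 uM (on this read-out lower numbers stand for stronger inhibition and higher numbers for weaker inhibition), so far. Compound 1 `Cc1cc(Nc2ccc(C(=O)/C=C/c3ccc(F)cc3)cc2)n2nc(SCc3nc4ccccc4[nH]3)nc2n1` gives 85 nM there, the middle number of the three. Compound 3 `Cc1cc(Nc2ccc(C(=O)/C=C/c3ccc4ccccc4c3)cc2)n2nc(SC(=O)c3csc4ccc(Cl)cc34)nc2n1` gives 35 nM as the lowest number, and it differs from compound 1 in several places. Compound 2 `Cc1cc(Nc2ccc(C(=O)/C=C/c3ccc(OC(F)(F)F)cc3)cc2)n2nc(SCc3nc4ccccc4[nH]3)nc2n1` gives 220 nM as the highest.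

Compound 4 `Cc1cc(Nc2ccc(C(=O)/C=C/c3ccccc3)cc2)n2nc(SCc3nc4ccccc4[nH]3)nc2n1` has not yet been measured and differs from compound 1 at a single place. The counted difference is hydrogen in place of fluoro on an aromatic carbon and amounts to hydrogen in place of fluoro on an aromatic carbon, para to a large group.

Among the measured compounds shown here, only one measured step touches that same place: a 2.6-fold higher number from compound 1 to compound 2 (0.41 log units; beyond the scatter) for trifluoromethoxy in place of fluoro, a modest change beyond the scatter. That step puts another group on this carbon and does not remove the fluoro, so it offers a scale for changes here but no firm direction for hydrogen. A shift smaller than a 2.6-fold higher number from compound 1 to compound 2 (0.41 log units; beyond the scatter) is therefore expected in this assay here. The estimated step is a 1.3-fold higher number from compound 1 to compound 4 (0.11 log units; within the scatter) and is expected to stay within the scatter, with no clear direction. Compound 4 is estimated at 110 nM in this assay, with 40 nM to 300 nM as the expected range.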

Compound 4, half-maximal inhibitory concentration: 130 nM
Estimate against measurement, compound 4: 1.2-fold (0.07 log units) below; low and high end bracket the measured number.
By their numbers in this assay, from the lowest: compound 3; then compounds 1, 4 and 2 (each within the scatter of the next, the first and the last beyond it).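

In this assay, taking the substituent off this aromatic carbon altogether gives a 1.5-fold higher number from compound 1 to compound 4 (0.18 log units; within the scatter), and the other route to the same compound gives a 1.7-fold lower number from compound 2 to compound 4 (0.23 log units; within the scatter). Among the compounds shown here, until now this place had been seen only with fluoro and trifluoromethoxy, two groups whose compounds lie beyond the scatter of each other; the phenyl compound now shows that a number in this range needs neither group, since hydrogen stays within the scatter of both. No supporting data on why this carbon responds as it does accompany these results, so the values describe the size of the steps and nothing more.

The compounds shown leave open whether a group of another kind on this carbon, such as an amine, a hydroxyl or a carboxylic acid, would move the number beyond the scatter of the hydrogen compound. They also leave open whether the swap of fluoro for hydrogen would read the same with a group other than the sulfur-linked benzimidazolylmethyl side of compound 1 on the shared core.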